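The source may report more compounds than this note shows. Statements on the series, on what has been measured and on what is new or still open speak of the compounds shown alone.

Measured so far:
compound 1 `O=C1CC(c2ccc(Cl)cc2)Nc2c(Br)cc(Br)cc21` – > 100000 nM
compound 2 `O=C1CC(c2ccc([N+](=O)[O-])cc2)Nc2c(Br)cc(Br)cc21` – > 100000 nM

Both values come from a functional assay on MCF7 cells (Homo sapiens) for cytotoxicity, read by sulforhodamine B assay, with a stated time of 48 h; a higher number here means that more compound is tolerated, a lower number that less compound is tolerated. For compound 1 the figure is a limit of the assay, not a number. For compound 2 likewise only a limit is reported, so compound 2 stands on no readable value in this assay; both known points sit at the limit of > 100000 nM in this assay, at which 2 of the 2 values shown sit. The step from compound 1 to compound 2 is a step that the two limits leave unreadable from compound 1 to compound 2, nitro in place of chloro on an aromatic carbon, and its size cannot be read from the two limits.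

The next compound is compound 3 `N#Cc1ccc(C2CC(=O)c3cc(Br)cc(Br)c3N2)cc1`. It differs from compound 2 in one place: cyano in place of nitro on an aromatic carbon. For the measured compounds named here, only one measured step bears on a change at this position, and that step is unreadable, so it gives no direction for this assay. With both neighbours at the limit, the expectation is that compound 3 again falls at or beyond it, a step that the limit leaves unreadable from compound 2 to compound 3 from compound 2. The estimate for compound 3 is therefore 150000 nM, in the range 50000 nM to 500000 nM, most likely reported as a limit only.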

Compound 3, concentration lethal to 50% of the cells: > 100000 nM
Compound 3 was reported as a limit; the forecaster's own chance of this, stated with the estimate: 80%; the middle value lies beyond the limit too.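

In this assay no step can be read among compound 1, compound 2 and compound 3; each reported value is a limit, not a number. Still open is whether chloro, nitro and cyano differ at all in these compounds, as the values give no readable number and all stand at one limit: the limit of > 100000 nM in this assay, at which 3 of the 3 values shown sit.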